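A few compounds are considered here, and "the series" means these few. Any claim that something is new, unique, unknown or untested is made for them only; others in the source may bear on it.

In a functional assay on IMR-32 cells (Homo sapiens) for antiproliferative activity, read by sulforhodamine B assay, with a stated time of 48 h (a lower number here means a stronger inhibitor of growth, a higher number a weaker inhibitor of growth), compound 3 `O=C1COc2ccccc2N1CCCn1cc(CCCCl)nn1` gives 200 nM, compound 1 `O=C1COc2ccccc2N1CCCn1cc(-c2ccccc2)nn1` gives 370 nM and compound 2 `O=C1COc2ccccc2N1CCCn1cc(CO)nn1` gives 5500 nM. Compound 3 thus stands at the low end together with compound 1, with a 1.9-fold lower number from compound 1 to compound 3 (0.27 log units; within the scatter), and far from compound 2, with a 28-fold lower number from compound 2 to compound 3 (1.44 log units; beyond the scatter). Compound 4 `O=C1COc2ccccc2N1CCCn1cc(C2(O)CCCCC2)nn1` has 1-hydroxycyclohexyl in place of 3-chloropropyl on an aromatic carbon. Compound 2 also carries a hydroxy group, and hydroxymethyl in place of phenyl gave a 15-fold higher number from compound 1 to compound 2 (1.17 log units; beyond the scatter), which argues for an upward move. Among the measured compounds shown here, the carbon ring of compound 4 has no direct precedent, so only part of that large step is expected. The expected change is a 4.0-fold higher number from compound 3 to compound 4 (0.60 log units; beyond the scatter). For compound 4 the estimate is 800 nM, with an expected range of 250 nM to 3000 nM.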

Compound 4, concentration for 50% growth inhibition: 1200 nM
The estimate for compound 4 lay 1.5-fold (0.18 log units) below the measured number; the measured number falls inside the stated range.
By their numbers in this assay, from the lowest: compounds 3 and 1 (each within the scatter of the next); then compound 4; then compound 2.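

Replacing 3-chloropropyl with 1-hydroxycyclohexyl gives a 6.0-fold higher number from compound 3 to compound 4 (0.78 log units; beyond the scatter), and replacing phenyl with it gives a 3.2-fold higher number from compound 1 to compound 4 (0.51 log units; beyond the scatter), so both hydroxy-bearing groups shown, hydroxymethyl and 1-hydroxycyclohexyl, stand above the two groups without hydroxy. Hydroxy alone does not set the level at this position: 1-hydroxycyclohexyl in place of hydroxymethyl gives a 4.6-fold lower number from compound 2 to compound 4 (0.66 log units; beyond the scatter). Nothing available bears on the origin of these steps.

The compounds shown leave open where a plain cyclohexyl without the hydroxy would stand. They also leave open whether an amine at the end of a propyl chain would match 3-chloropropyl.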